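From Ethynyl to a Chlorophenyl Triazole on the Chain

The source may hold more compounds than are shown below. What is called first, only, known or untested is meant among the compounds shown, and "the series" means these compounds.

Of the compounds shown here, two with the same core have been measured so far. In a functional assay on MDA-MB-231 cells (Homo sapiens) for antiproliferative activity, read by MTT assay, with a stated time of 48 h (a lower number here means a stronger inhibitor, a higher number a weaker inhibitor), compound 2 (`C#CCOC(=O)/C(C)=C/CC/C(C)=C/CC/C(C)=C/CC[C@@H]1[C@@]2(C)CCC(=O)C(C)(C)[C@H]2CC[C@@]1(C)O`) gives 114000 nM and so holds the higher of the two numbers. Compound 1 (`C/C(=C\CC/C(C)=C/CC[C@@H]1[C@@]2(C)CCC(=O)C(C)(C)[C@H]2CC[C@@]1(C)O)CC/C=C(\C)C(=O)OCc1cn(C[C@@H]2O[C@H](n3ccc(=O)[nH]c3=O)C[C@H]2O)nn1`) gives 26300 nM in the same test, and the gap between the two lies beyond the usual scatter.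

The next compound is compound 3 (`C/C(=C\CC/C(C)=C/CC[C@@H]1[C@@]2(C)CCC(=O)C(C)(C)[C@H]2CC[C@@]1(C)O)CC/C=C(\C)C(=O)OCc1cn(-c2ccccc2Cl)nn1`), which has 1-(2-chlorophenyl)-1H-1,2,3-triazol-4-yl in place of ethynyl on a saturated chain carbon bound to an oxygen next to a carbonyl group. Within the data shown here, no measured pair isolates this change. The closest guide is compound 1 at 26300 nM. Compound 1 also carries a triazole at that place instead of ethynyl, although the group on its triazole is different. A moderate drop beyond the scatter is therefore expected in this assay, with compound 3 landing close to compound 1. The estimated change is a 3.3-fold lower number from compound 2 to compound 3 (0.51 log units; beyond the scatter) and remains uncertain. For compound 3 the expected value is 35000 nM within an estimated range of 12000 nM to 100000 nM in this test.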

Compound 3, half-maximal inhibitory concentration: > 150000 nM
Compound 3 ended at the assay's limit (the forecaster's own chance of this, stated with the estimate: 10%); middle value at least 4.2-fold (0.63 log units) from the limit.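

Compound 3 has no number in this assay, only a limit of the test: the limit of > 150000 nM in this assay, at which 1 of the 3 values shown sits. On these data alone, replacing ethynyl with 1-(2-chlorophenyl)-1H-1,2,3-triazol-4-yl on a saturated chain carbon bound to an oxygen next to a carbonyl group gives an at least 1.3-fold higher number from compound 2 to compound 3 (0.11 log units; that floor lies within the scatter), so only a floor can be read and the true size of the step is unknown. Compound 1, which also carries a triazole at this place but with a different group on it, gives 26300 nM in this assay, which shows what the earlier pair could not: a triazole here does not by itself bring the lower number, and the outcome depends on what the triazole carries.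

The compounds shown leave open whether the chlorine or the phenyl ring of compound 3 goes with the loss of a measurable number, and a triazole bearing a plain phenyl would separate the two. They also leave open how a triazole carrying a short chain that ends in an amine or a carboxylic acid would read in this assay.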